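Chain extension on the aryl arm of the series

A few compounds are considered here, and "the series" means these few. Any claim that something is new, unique, unknown or untested is made for them only; others in the source may bear on it.

Compound 1 `Nc1nc(N2CCN(C(=O)COc3ccc(Cl)cc3)CC2)c2nc(-c3ccc(F)cc3)sc2n1` gives 490 nM in a functional assay on cells (Lymphocyte, Homo sapiens); a higher number here means a weaker inhibitor, a lower number a stronger inhibitor. Within the data shown here, compound 2 `Nc1nc(N2CCN(C(=O)COc3ccc(Cl)cc3)CC2)c2nc(Cc3ccc(F)cc3)sc2n1` gives 700 nM in this assay and stands highest of the two numbers so far, although the step of a 1.4-fold higher number from compound 1 to compound 2 (0.15 log units; within the scatter) lies within the scatter. Compound 3 `Nc1nc(N2CCN(C(=O)COc3ccc(Cl)cc3)CC2)c2nc(CCOc3ccc(F)cc3)sc2n1` carries the change ((4-fluorophenoxy)methyl in place of 4-fluorophenyl on a saturated chain carbon bound to an aromatic carbon). Among the measured compounds shown here, the only measured step bearing on such lengthening is a 1.4-fold higher number from compound 1 to compound 2 (0.15 log units; within the scatter), which stayed within the scatter, so in this assay no step beyond the scatter is expected, with at most a slight lean toward a higher number. Compound 3 is estimated at 900 nM, ranging from 400 nM to 2000 nM, an expected step of a 1.3-fold higher number from compound 2 to compound 3 (0.11 log units; within the scatter).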

Compound 3, half-maximal inhibitory concentration: 3540 nM
Compound 3: the middle estimate sits 3.9-fold (0.59 log units) below what was measured; measured number outside the range, above it.
By their numbers in this assay, from the lowest: compounds 1 and 2 (each within the scatter of the next); then compound 3.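

Among these compounds, on an aromatic carbon of the shared core, the first step beyond the scatter appears with 2-(4-fluorophenoxy)ethyl: in this assay, there is a 5.1-fold higher number from compound 2 to compound 3 (0.70 log units; beyond the scatter), and against directly attached 4-fluorophenyl there is a 7.2-fold higher number from compound 1 to compound 3 (0.86 log units; beyond the scatter). This change adds both chain length and an oxygen, and these compounds cannot separate the two. No available data explain the rise.

As far as these compounds go, it remains open whether an all-carbon 3-(4-fluorophenyl)propyl group would match compound 3, or whether the oxygen matters apart from chain length.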